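The compounds below may be only part of what the source reports. "The series", "measured", "known", "first", "only" and "open" are said of these compounds alone.

Compounds measured so far:
compound 1, `O=C(NCN1CCC(c2cccc[n+]2[O-])CC1)c1ccccc1`: 532 nM
compound 2, `O=C(CN1CCC(c2cccc[n+]2[O-])CC1)Nc1ccc(F)cc1F`: 103 nM
compound 3, `Cc1cccc(NC(=O)CN2CCC(c3ccc(O)cc3)CC2)c1`: 70 nM

All three numbers come from a functional assay on HEK293 cells for agonist activity at D(4) dopamine receptor (Homo sapiens), read by FLIPR; on this read-out lower numbers stand for an effect already at smaller amounts and higher numbers for an effect only at larger amounts of compound. Compound 2 stands second highest of the three: compound 3 gives a value within the scatter of it, while compound 1 gives the higher number and lies beyond the scatter. No pair among these three differs in one place only, so no single-change step can be read from them.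

Compound 4, `O=C(CN1CCC(c2cccc[n+]2[O-])CC1)Nc1cccc(Cl)c1`, is not yet measured. It differs from compound 2 by 3-chlorophenyl in place of 2,4-difluorophenyl on an amide-type nitrogen. Nothing measured bears on this exchange, so the step of a 1.2-fold higher number from compound 2 to compound 4 (0.07 log units; within the scatter) is expected to stay within the scatter, in no particular direction. For compound 4 the estimate in this assay is 120 nM, with a range from 40 nM to 400 nM.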

Compound 4, half-maximal effective concentration: 62 nM
For compound 4 the middle estimate is 1.9-fold (0.29 log units) above the measured one; the measured number falls inside the stated range.
By their numbers in this assay, from the lowest: compounds 4, 3 and 2 (each within the scatter of the next); then compound 1.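

In this assay, going by these compounds alone, 3-chlorophenyl in place of 2,4-difluorophenyl on the amide-type nitrogen gives a 1.7-fold lower number from compound 2 to compound 4 (0.22 log units; within the scatter), the first single-change step. This read-out therefore does not separate these two groups at this position, although a single exchange says little about the position as a whole. No available evidence bears on this step.

On these data alone, how an amine or a carboxylic acid in place of the chlorine on that ring would read stays open. Also open, as far as these compounds go, is whether the same exchange reads alike on the core of compound 3.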